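From phenyl to hexyl at the assay limit

The source may hold more compounds than are shown below. What is called first, only, known or untested is meant among the compounds shown, and "the series" means these compounds.

Measured in a functional assay on RAW264.7 cells (Mus musculus) for inhibition, read by Griess assay, with a stated time of 20 h; on this read-out lower numbers stand for stronger inhibition and higher numbers for weaker inhibition:
- compound 1 `CCCNC(=O)c1cc(-n2cc(-c3ccccc3)nn2)ccc1O`: > 20000 nM (a limit)
- compound 2 `CCCNC(=O)c1cc(-n2cc(-c3cc(C(F)(F)F)cc(C(F)(F)F)c3)nn2)ccc1O`: > 20000 nM (a limit)
- compound 3 `O=C(c1cc(-n2cc(-c3ccccc3)nn2)ccc1O)N1CCCCC1`: > 20000 nM (a limit)

Compound 3 has no exact number, only the limit > 20000 nM. It shares that position with the other two measured compounds: the limit of > 20000 nM in this assay, at which 3 of the 3 values shown sit.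

Compound 4 `CCCCCCc1cn(-c2ccc(O)c(C(=O)N3CCCCC3)c2)nn1` has hexyl in place of phenyl on an aromatic carbon of a five-membered aromatic ring with 3 nitrogen (hexyl in place of phenyl on an aromatic carbon).

Among the compounds with values here, the only measured step, a step that the two limits leave unreadable from compound 1 to compound 3, involves a different change and gives no size to carry over. A clear gain in this assay is therefore not expected, although it cannot be ruled out. The expected result is a number no higher from compound 3 to compound 4 (the limit leaves the size open). The estimate for compound 4 is 20000 nM, with an expected range from 7000 nM to 40000 nM.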

Compound 4, half-maximal inhibitory concentration: > 20000 nM
Compound 4: only a limit was reported (the forecaster's own chance of this, stated with the estimate: 65%); the middle value lies on the limit itself.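

No step can be read between compound 3 and compound 4, since each gives only a limit, not a number: the limit of > 20000 nM in this assay, at which 4 of the 4 values shown sit.

The compounds shown leave open how strongly any of them inhibits, and whether hexyl differs from phenyl at all.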